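A few compounds are considered here, and "the series" means these few. Any claim that something is new, unique, unknown or untested is made for them only; others in the source may bear on it.

Measured compounds in an assay on a protein complex for inhibition of ubiquitin carboxyl-terminal hydrolase 1/WD repeat-containing protein 48 (Homo sapiens), read by fluorescence; on this read-out lower numbers stand for stronger inhibition and higher numbers for weaker inhibition:

- compound 1 `CC(C)c1ccccc1-c1nc(NCc2ccc(-c3cccnc3)cc2)c2sccc2n1`: 110 nM
- compound 2 `Cc1cccc(CNc2nc(-c3ccccc3C(C)C)ncc2C)c1`: 130 nM
- compound 3 `Cc1cnc(-c2ccccc2C(C)C)nc1NCc1cccnc1`: 1300 nM

Compound 3 has the highest number of the three. Among the compounds with values here, its nearest neighbour is compound 2, and the only single-point step among the measured compounds, a 10-fold higher number from compound 2 to compound 3 (1.00 log units; beyond the scatter), is exactly the one that separates them: exchanging 3-methylphenyl for pyridin-3-yl on the saturated chain carbon bound to a nitrogen on the aromatic ring lifts the number well beyond the scatter. Compound 1, on a different core, stands further away from compound 3 still.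

Compound 4 `Cc1cnc(-c2ccccc2C(C)C)nc1NCc1cccs1` is not yet measured. It differs from compound 3 in one place: thiophen-2-yl in place of pyridin-3-yl on a saturated chain carbon bound to a nitrogen on an aromatic ring. The move is again at the methylene-linked aryl group, the same position that carried the step from compound 2 to compound 3. That step shows the position to be sensitive; thiophen-2-yl, like 3-methylphenyl, brings a ring without a nitrogen, but it is a five-membered ring, smaller than either group already tested. Nothing measured shows thiophen-2-yl directly, so the expectation is a partial return toward the number of compound 2 rather than a full one.

Compound 4 is therefore expected at 400 nM, within 130 nM to 1300 nM, an estimated step of a 3.3-fold lower number from compound 3 to compound 4 (0.51 log units; beyond the scatter) in this assay.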

Compound 4, half-maximal inhibitory concentration: 270 nM
Compound 4: the middle estimate sits 1.5-fold (0.17 log units) above what was measured, and the stated range covers the measured number.
By their numbers in this assay, from the lowest: compounds 1 and 2 (each within the scatter of the next); then compound 4; then compound 3.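

In this assay, thiophen-2-yl on the saturated chain carbon bound to a nitrogen on an aromatic ring gives a 4.8-fold lower number from compound 3 to compound 4 (0.68 log units; beyond the scatter), so a lower number at this position does not depend on a six-membered ring. Among the three groups compared on the shared core, pyridin-3-yl, the only one with a ring nitrogen, gives the highest number; neither of the other two goes against this, but three groups make only a narrow pattern. The replacement does not fully match 3-methylphenyl, with a 2.1-fold higher number from compound 2 to compound 4 (0.32 log units; beyond the scatter) a small step but one printed as beyond the scatter, and nothing available here explains the order of the three groups.

Pyridin-3-yl and thiophen-2-yl differ in ring size and in hetero atom at once, and 3-methylphenyl also carries a methyl group, so the contribution of each feature remains unseparated. As far as these compounds go, how a plain phenyl, a furan-2-yl or a saturated piperidine ring would read at this position remains open, as does whether the order of these groups would hold on the core of compound 1.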